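A few compounds are considered here, and "the series" means these few. Any claim that something is new, unique, unknown or untested is made for them only; others in the source may bear on it.

Compound 2 `CCCOC(=O)c1c(C)coc1-c1ccc2c(CC)cccc2c1OC` gives only a limit in a functional assay on MDA-MB-231 cells (Homo sapiens) for cytotoxicity, read by MTT assay, with a stated time of 72 h; a higher number here means that more compound is needed for the effect, a lower number that less compound is needed: compound 2 reaches > 10 ug/mL. Compound 1 `CCc1cccc2c(OC)c(-c3occ(C)c3C(=O)OC)ccc12` gives 1.3 ug/mL in this assay, and the step of an at least 7.6-fold higher number from compound 1 to compound 2 (0.88 log units; beyond the scatter) shows a larger ester costing activity. Compound 3 `CCc1cccc2c(OC)c(-c3occ(C)c3C(=O)On3nnc4ccccc43)ccc12` takes this further: a group of 9 heavy atoms (6 carbon, 3 nitrogen; one five-membered aromatic ring with 3 hetero atoms, one six-membered aromatic ring of carbon only) in place of a group of 3 heavy atoms (3 carbon; no ring), on an oxygen next to a carbonyl group. Among the compounds with values here, with compound 2 already sitting at the limit of > 10 ug/mL in this assay, at which 1 of the 2 values shown sits, the one measured step only hints that a still bulkier ester group may not recover activity, yet the entering aromatic rings are unlike anything measured here. Compound 3 is therefore expected to move by an at least 1.2-fold lower number from compound 2 to compound 3 (0.09 log units; that floor lies within the scatter), to an estimated 8 ug/mL, within 1.5 ug/mL to 40 ug/mL.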

Compound 3, concentration for half-maximal effect: > 10 ug/mL
Compound 3 gave a limit, no number; the forecaster's own chance of this, stated with the estimate: 45%; at least 1.2-fold (0.09 log units) between middle value and limit.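

In this assay compound 3 gives > 10 ug/mL, which is a limit and not a number. The group with the aromatic rings, in place of one carbon atom on an oxygen next to a carbonyl group, brings an at least 7.6-fold higher number from compound 1 to compound 3 (0.88 log units; beyond the scatter), so a ring-bearing group at this place, not only the propyl chain, goes with a higher number. The step between the two large esters cannot be read, and the values now collect at one limit: the limit of > 10 ug/mL in this assay, at which 2 of the 3 values shown sit. As far as these compounds go, what a carboxylic acid or an amide at this place would give stays open, as does how far compound 2 and compound 3 actually lie beyond the limit.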